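A few compounds are considered here, and "the series" means these few. Any claim that something is new, unique, unknown or untested is made for them only; others in the source may bear on it.

Compound 3 `Cn1cc(-c2ccccc2NCC2=NCCN2)cn1` carries the shared core of compound 1 `Cn1nccc1-c1ccccc1NCC1=NCCN1` with a 1-methyl-1H-pyrazol-4-yl group on an aromatic carbon. In an in vitro functional assay on cells (Fibroblast) for agonist activity at Alpha-1D adrenergic receptor (Homo sapiens) (on this read-out higher numbers stand for an effect only at larger amounts of compound and lower numbers for an effect already at smaller amounts), compound 3 gives only a limit, < 100000 nM. Compound 1 likewise gives only a limit in this assay, < 100000 nM. Compound 2 `c1ccc(-c2cn[nH]c2)c(NCC2=NCCN2)c1` gives 20 nM in this assay. Compound 4 `CCn1cc(-c2ccccc2NCC2=NCCN2)cn1` differs from compound 3 by methyl in place of hydrogen on a saturated chain carbon bound to an aromatic nitrogen. The nearest measured step is a step that the limit leaves unreadable from compound 2 to compound 3; the steps a step that the limit leaves unreadable from compound 1 to compound 2 and a step that the two limits leave unreadable from compound 1 to compound 3 are equally unreadable because of the limit of < 100000 nM in this assay, at which 2 of the 3 values shown sit. Among the compounds with values here, no measured step therefore fixes a size or direction for methyl to ethyl here, and compound 3 itself stands only at a limit. Compound 4 is expected to stay at that limit, so the step of a number no lower from compound 3 to compound 4 (the limit leaves the size open) is estimated as none readable. The estimate for compound 4 is 100000 nM, within 5000 nM to 500000 nM.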

Compound 4, half-maximal effective concentration: < 100000 nM
Compound 4: no number, only a limit (the forecaster's own chance of this, stated with the estimate: 80%); the middle value sits exactly at the limit.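

In this assay, compound 4 gives only a limit, so its steps from compound 3 and compound 2 cannot be read: the limit of < 100000 nM in this assay, at which 3 of the 4 values shown sit. The compounds shown leave open the size and direction of the methyl to ethyl change.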